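The source may report more compounds than this note shows. Statements on the series, on what has been measured and on what is new or still open speak of the compounds shown alone.

Measured compounds:
Compound 1, `O=C(Nc1ccc(Sc2nc3ccccc3s2)cc1)c1cc(Br)cc(Br)c1O`: 21000 nM
Compound 2, `O=S(=O)(Nc1ccc(-c2nc3cc(NS(=O)(=O)c4ccc(C(F)(F)F)cc4)ccc3o2)cc1)c1ccc(C(F)(F)F)cc1`: 13000 nM

In a functional assay on HT-29 cells (Homo sapiens) for cytotoxicity, read by resazurin assay, with a stated time of 48 h (a lower number here means that less compound is needed, a higher number that more compound is needed for the effect), compound 1 gives 21000 nM, the highest of the two numbers shown, while compound 2 gives 13000 nM, which lies within the scatter of compound 1. Compound 3, `COc1c(Br)cccc1C(=O)Nc1ccc(Sc2nc3ccccc3s2)cc1`, differs from compound 1 in one place: a group of 9 heavy atoms (7 carbon, 1 oxygen, 1 bromine; one six-membered aromatic ring of carbon only) in place of a group of 9 heavy atoms (6 carbon, 1 oxygen, 2 bromine; one six-membered aromatic ring of carbon only), on a carbonyl carbon. Going by the values given here, no measured pair shows this kind of change, so its size is unknown here. The step from compound 1 to compound 3 is expected to be a 1.4-fold higher number from compound 1 to compound 3 (0.15 log units; within the scatter), little beyond the scatter. Compound 3 is estimated at 30000 nM, within 9000 nM to 100000 nM.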

Compound 3, half-maximal effective concentration: 30000 nM
Compound 3: middle estimate and measured number agree at the digits printed; measured number inside the range.
By their numbers in this assay, from the lowest: compounds 2, 1 and 3 (each within the scatter of the next, the first and the last beyond it).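

In this assay, the first step read at this position, on the carbonyl carbon, is a 1.4-fold higher number from compound 1 to compound 3 (0.15 log units; within the scatter). The group that enters has 0 hydrogen-bond donors and 1 bromine, against 1 donor and 2 bromines in 3,5-dibromo-2-hydroxyphenyl, yet the two numbers stay within the scatter of each other. No outside measurement bears on this result. The donor and the bromine change together in this one step, and their separate contributions cannot be told apart. As far as these compounds go, whether a group carrying an amine or a carboxylic acid at this position would give a different number remains open.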